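Swapping an isobutoxyphenyl for an indole: cytotoxicity expectations

A few compounds are considered here, and "the series" means these few. Any claim that something is new, unique, unknown or untested is made for them only; others in the source may bear on it.

Of the compounds shown here, three have been measured in an ADME assay on Raji cells (Homo sapiens) for cytotoxicity, read by CellTiter-Glo and resazurin assay, with a stated time of 72 h; on this read-out higher numbers stand for an effect only at larger amounts of compound and lower numbers for an effect already at smaller amounts. Compound 1, `CC(C)N(Cc1cccc(OCCCCCC(=O)O)c1)C(=O)c1ccccc1`, gives only the assay limit > 26000 nM. Compound 2, `CC(C)COc1cccc(-c2ccc(C(=O)N(Cc3cccc(OCCCCCC(=O)O)c3)C(C)C)cc2)c1`, gives only the assay limit > 26000 nM. Compound 3, `CC(C)N(Cc1cccc(OCCCCCC(=O)O)c1)C(=O)c1ccc(-c2cccc(OCc3ccccc3)c2)cc1`, gives only the assay limit > 26000 nM.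

Compound 2 thus stands at the limit of > 26000 nM in this assay, at which 3 of the 3 values shown sit. The two measured steps that touch it, a step that the two limits leave unreadable from compound 1 to compound 2 and a step that the two limits leave unreadable from compound 2 to compound 3, are both unreadable because the limit of > 26000 nM in this assay, at which 3 of the 3 values shown sit, caps every value. The untested compound 4, `CC(C)N(Cc1cccc(OCCCCCC(=O)O)c1)C(=O)c1ccc(-c2ccc3[nH]ccc3c2)cc1`, differs from compound 2 by 1H-indol-5-yl in place of 3-(isobutoxy)phenyl on an aromatic carbon. Among the measured compounds shown here, no measured step gives a readable size, so for compound 4 the expected step that the limit leaves unreadable from compound 2 to compound 4 cannot be set beyond the limit with confidence. Compound 4 is therefore estimated at 30000 nM, within 10000 nM to 100000 nM, most likely again reported only as a limit.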

Compound 4, half-maximal effective concentration: > 26000 nM
Compound 4: no number, only a limit; the forecaster's own chance of this, stated with the estimate: 85%; the middle value is on the limit's open side.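

Neither the step from compound 1 to compound 4 nor the step from compound 2 to compound 4 can be read, because each compares two limits: the limit of > 26000 nM in this assay, at which 4 of the 4 values shown sit.

The compounds shown leave open what concentration of any of them would give an effect in this assay.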